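This account rests on a few compounds, and the source may have more. Where it says the series, first, only, none or still open, it means among the compounds named here.

Measured so far in a functional assay on MDA-MB-231 cells (Homo sapiens) for inhibition, read by MTT assay, with a stated time of 48 h; on this read-out lower numbers stand for stronger inhibition and higher numbers for weaker inhibition:
Compound 1 `COc1cc(/C=C/c2ccc(NC(=O)/C=C/c3cc(OC)c(OC)c(OC)c3)cc2)cc(OC)c1` gives 2140 nM.
Compound 2 `COc1cc(/C=C/c2ccc(NC(=O)/C=C/c3ccc(F)cc3)cc2)cc(OC)c1` gives 9390 nM.
Compound 3 `COc1cc(/C=C/c2ccc(NC(=O)/C=C/c3ccc(Cl)cc3)cc2)cc(OC)c1` gives 14100 nM.

Compound 2 sits second highest of these three numbers. Its nearest neighbour is compound 3, reached by a 1.5-fold higher number from compound 2 to compound 3 (0.18 log units; within the scatter); its furthest is compound 1, whose number is lower by a margin beyond the scatter. Compound 4 `COc1cc(/C=C/c2ccc(NC(=O)/C=C/c3ccc(O)c(O)c3)cc2)cc(OC)c1` differs from compound 2 in one place: 3,4-dihydroxyphenyl in place of 4-fluorophenyl on a double-bonded chain carbon bound to a double-bonded chain carbon. Within the data shown here, only one measured step is a single change of the same kind, a 1.5-fold higher number from compound 2 to compound 3 (0.18 log units; within the scatter), and it swaps one halogen for another rather than bringing in hydroxyl groups, so it says little about compound 4. Compound 1, which also carries oxygen-bearing groups on the ring that is exchanged here, gives a lower number than compound 2, but no single-step comparison between those two exists. Compound 4 is therefore expected to give a somewhat lower number than compound 2, by an estimated 2.3-fold lower number from compound 2 to compound 4 (0.37 log units; beyond the scatter), though with wide uncertainty. The estimate for compound 4 is 4000 nM, with an expected range from 1500 nM to 11000 nM.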

Compound 4, half-maximal inhibitory concentration: 4230 nM
For compound 4 the middle estimate is 1.1-fold (0.02 log units) below the measured one; the range from low to high includes it.
By their numbers in this assay, from the lowest: compounds 1 and 4 (each within the scatter of the next); then compounds 2 and 3 (each within the scatter of the next).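

In this assay, the ring on this double-bonded chain carbon matters more than the earlier halogen swap suggested: a 1.5-fold higher number from compound 2 to compound 3 (0.18 log units; within the scatter) was small, but putting 3,4-dihydroxyphenyl in place of a halogen-bearing ring gives a 2.2-fold lower number from compound 2 to compound 4 (0.35 log units; beyond the scatter) and a 3.3-fold lower number from compound 3 to compound 4 (0.52 log units; beyond the scatter). Compound 4 also lies within the scatter of compound 1, so the two compounds with oxygen-bearing rings here, hydroxyl groups in one and methoxy groups in the other, both give lower numbers than the two halogen-bearing compounds. Nothing in the available data explains why the number falls with this change.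

The compounds shown leave open whether both hydroxyl groups are needed or a single one would serve. They also leave open how a ring carrying an amine or a carboxylic acid would read at this position.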